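Methyl in place of hydrogen on the amino side chain

This account rests on a few compounds, and the source may have more. Where it says the series, first, only, none or still open, it means among the compounds named here.

Compound 1 `CC(C)C(C)NC1=NS(=O)(=O)c2cnccc2N1`: in a functional assay (ileum) for inhibition, with Cavia porcellus as the target (on this read-out lower numbers stand for stronger inhibition and higher numbers for weaker inhibition), compound 1 gives only the limit > 300000 nM.
Compound 2 `CC(C)Nc1nc(O)c2cc(Cl)ccc2n1`: in this assay compound 2 gives 74100 nM.

Among the measured compounds shown here, compound 2 holds the only numerical value in this assay. Compound 1 sits at the limit of > 300000 nM in this assay, at which 1 of the 2 values shown sits, a limit and not a number. Compound 3 `CCC(C)Nc1nc(O)c2cc(Cl)ccc2n1` differs from compound 2 by methyl in place of hydrogen on a saturated chain carbon, two bonds along the chain from a nitrogen on an aromatic ring. For the measured compounds named here, no step between measured compounds is available to size such a change. With nothing to set its scale, the step of a 1.2-fold lower number from compound 2 to compound 3 (0.09 log units; within the scatter) is estimated to stay within the usual scatter, in no firm direction. Compound 3 is therefore expected to give about 60000 nM, between 20000 nM and 200000 nM.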

Compound 3, half-maximal inhibitory concentration: 44700 nM
Beside the measured number, compound 3's estimate is 1.3-fold (0.13 log units) above it; measured number inside the range.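

Among the compounds shown here, the first sized step at this position is a 1.7-fold lower number from compound 2 to compound 3 (0.22 log units; within the scatter) in this assay and it reads as isopropylamino to (sec-butyl)amino. Methyl in place of hydrogen on this saturated chain carbon therefore leaves the number within the scatter, so this added carbon has no measurable effect here. Nothing shown bears on the reason for this step.

The compounds shown leave open whether a longer chain, such as n-pentyl, or a cyclohexyl ring on the amino nitrogen would move the number beyond the scatter. A single methyl step also cannot show how a hydroxyl on this chain carbon would read.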